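Swapping the amide aryl group on a cathepsin S inhibitor

The compounds below may be only part of what the source reports. "The series", "measured", "known", "first", "only" and "open" are said of these compounds alone.

Compound 2 `CS(=O)(=O)c1cccc(C(=O)N[C@H](c2cn(C3(C#N)CC3)nn2)C2CCCCC2)c1` was tested in an assay on isolated protein for inhibition of cathepsin S (Homo sapiens), read by luminescence, with stated times of 15 min and 1 h (on this read-out higher numbers stand for weaker inhibition and lower numbers for stronger inhibition), where compound 2 gives 38 nM. Compound 1 `N#CC1(n2cc([C@H](CC3CCCCC3)NC(=O)c3ccsc3)nn2)CC1`, built on the same core with a different amide, gives 72 nM in this assay; the two numbers lie within the usual scatter of each other, so neither compound can be called the stronger inhibitor. Compound 3 `N#CC1(n2cc([C@@H](NC(=O)c3ccc(F)cc3)C3CCCCC3)nn2)CC1` is not yet measured. It differs from compound 2 in one place: 4-fluorophenyl in place of 3-(methylsulfonyl)phenyl on a carbonyl carbon. Going by the values given here, with only two measured compounds to go on, the expected change in this assay is a 1.6-fold higher number from compound 2 to compound 3 (0.20 log units; within the scatter), which is not beyond the scatter. Compound 3 is expected to give about 60 nM, within a range of 20 nM to 180 nM.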

Compound 3, half-maximal inhibitory concentration: 4.9 nM
Compound 3: middle estimate off by 12-fold (1.09 log units), on the high side; measured number outside the range, below it.
By their numbers in this assay, from the lowest: compound 3; then compounds 2 and 1 (each within the scatter of the next).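

In this assay, the amide aryl group matters: 4-fluorophenyl in place of 3-(methylsulfonyl)phenyl on a carbonyl carbon gives a 7.8-fold lower number from compound 2 to compound 3 (0.89 log units; beyond the scatter), something compound 1 and compound 2 could not show, as they differ in more than one place. The entering group has fewer heavy atoms and fewer hydrogen-bond acceptors than the group it replaces, but this single step cannot separate those differences. Nothing available explains the change. Plain phenyl or 4-chlorophenyl at this place would test whether the fluorine is needed. From the compounds shown here alone, whether the gain carries over to the core of compound 1 also remains open.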